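Triazolylmethyl amides on the shared core: step to compound 4

The source may hold more compounds than are shown below. What is called first, only, known or untested is meant among the compounds shown, and "the series" means these compounds.

Measured so far:
compound 1 `CC(C)n1ncc2c(C(=O)Nc3ccccc3)cccc21` — 23700 nM
compound 2 `CC(C)n1ncc2c(C(=O)NC3CCCC3)cccc21` — > 40000 nM
compound 3 `Cc1ccc(-n2cc(CNC(=O)c3cccc4c3cnn4C(C)C)nn2)cc1` — > 40000 nM

All three share the core of compound 1 and differ only in the group on the amide nitrogen. In a functional assay on HepG2 cells (Homo sapiens) for inhibition, read by MTT assay, with a stated time of 72 h (on this read-out lower numbers stand for stronger inhibition and higher numbers for weaker inhibition), compound 1 gives 23700 nM. For compound 2 the read-out is a limit of the assay, > 40000 nM. The one step between neighbours, an at least 1.6-fold higher number from compound 1 to compound 2 (0.22 log units; that floor lies within the scatter), sits at a floor that lies within the scatter, so nothing beyond noise is shown there.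

Compound 3 stands at a limit of the assay, > 40000 nM, and so gives no number to anchor a step; note (the limit of > 40000 nM in this assay, at which 2 of the 3 values shown sit).

Compound 4 `COc1ccc(Cn2cc(CNC(=O)c3cccc4c3cnn4C(C)C)nn2)cc1` differs from compound 3 by 4-methoxybenzyl in place of 4-methylphenyl on an aromatic nitrogen. For the measured compounds named here, no measured step touches this position: the only measured step is on the amide-type nitrogen, not on the aromatic nitrogen of the five-membered ring with three nitrogens, so it gives no guide to direction or size here. The expectation for compound 4 rests on compound 3 alone, which sits at the limit, and the step of a number no higher from compound 3 to compound 4 (the limit leaves the size open) is therefore estimated as none beyond the scatter, with a good chance that this assay again reports only a limit. For compound 4 the estimate is 40000 nM, with a range from 10000 nM to 150000 nM.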

Compound 4, half-maximal inhibitory concentration: > 40000 nM
Compound 4 ended at the assay's limit; the forecaster's own chance of this, stated with the estimate: 65%; the middle value sits exactly at the limit.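

No step can be read from compound 3 to compound 4, as both results are limits and not numbers in this assay: the limit of > 40000 nM in this assay, at which 3 of the 4 values shown sit.

The compounds shown leave open whether 4-methoxybenzyl in place of 4-methylphenyl on the aromatic nitrogen changes the read-out at all, and how far either compound lies from that limit.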